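A Larger Chain Enters Where Compound 1 Carries a Methyl

A few compounds are considered here, and "the series" means these few. Any claim that something is new, unique, unknown or untested is made for them only; others in the source may bear on it.

Of the compounds shown here, three have been measured so far in a functional assay (B cells) with Mus musculus as the target; on this read-out lower numbers stand for an effect already at smaller amounts and higher numbers for an effect only at larger amounts of compound. Compound 1 `CCn1c(=O)n(C2OC(CO)[C@@H](O)[C@H]2O)c2nc(N)nc(O)c21` gives 15 uM in this assay. Compound 2 `C=CCn1c(=O)n(C2C=CC(CO)O2)c2nc(N)nc(O)c21` gives 6 uM, and compound 3 `C=CCn1/c(=N\C#N)n([C@H]2OC(CO)[C@@H](O)[C@H]2O)c2cc(N)nc(O)c21` gives 156 uM. On these numbers compound 1 stands second highest of the three: compound 2 lies nearest, with a lower number by a margin beyond the scatter, and compound 3 lies furthest, with a higher number that is also beyond the scatter.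

Compound 4 `Nc1nc(O)c2c(n1)n(C1OC(CO)[C@@H](O)[C@H]1O)c(=O)n2CC(O)CSc1ccccc1` has not yet been measured. It differs from compound 1 in one place: 1-hydroxy-2-(phenylsulfanyl)ethyl in place of methyl on a saturated chain carbon bound to an aromatic nitrogen. A methyl on the saturated chain carbon bound to an aromatic nitrogen is thus replaced by a 1-hydroxy-2-(phenylsulfanyl)ethyl group, which brings one six-membered aromatic ring of carbon only, one hydrogen-bond donor and two hydrogen-bond acceptors.

For the measured compounds named here, no two of the measured compounds differ in a single place, so no step of this kind has yet been seen in this assay. For the step of a 1.3-fold lower number from compound 1 to compound 4 (0.10 log units; within the scatter) the expectation is a change that stays within or only modestly beyond the scatter, with no clear direction. Compound 4 is therefore estimated at 12 uM, with a range from 3 uM to 50 uM.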

Compound 4, concentration for half-maximal effect: 142 uM
Compound 4: middle estimate off by 12-fold (1.07 log units), on the low side; measured number outside the range, above it.
By their numbers in this assay, from the lowest: compound 2; then compound 1; then compounds 4 and 3 (each within the scatter of the next).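

For the compounds shown here, this is the first step in this assay where only one place changes: putting 1-hydroxy-2-(phenylsulfanyl)ethyl in place of methyl on a saturated chain carbon bound to an aromatic nitrogen gives a 9.5-fold higher number from compound 1 to compound 4 (0.98 log units; beyond the scatter), which means an effect appears only at larger amounts of compound. The position is therefore not indifferent to what it carries, and this larger group goes with a loss rather than a gain on this read-out. The entering group brings an aromatic ring, a sulfur and a hydroxyl together, however, so this single step cannot show which of these parts goes with the higher number.

Nothing measured here gives a reason for the step. Still open, from the compounds shown here alone, is whether a small group such as hydroxymethyl, a plain propyl chain or a benzyl group, each carrying only part of what entered, would keep the number of compound 1 or move it as far as this step did.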